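Replacing acetyl with an arylsulfonyl group on the ring nitrogen

The source may report more compounds than this note shows. Statements on the series, on what has been measured and on what is new or still open speak of the compounds shown alone.

Compound 1 `CCN(CC)c1ccc2cc(C(=O)c3ccc(N4CCN(C(=O)COc5ccc(Cl)cc5Cl)CC4)cc3)oc2c1` gives 30 nM in a functional assay on HeLa cells (Homo sapiens) for cytotoxicity, read by MTT assay, with a stated time of 48 h; on this read-out lower numbers stand for stronger inhibition and higher numbers for weaker inhibition.
Compound 2 `CCN(CC)c1ccc2cc(C(=O)c3ccc(N4CCN(S(=O)(=O)c5ccc(Br)cc5)CC4)cc3)oc2c1` reaches only the limit of this assay, > 40000 nM.
Compound 3 `CCN(CC)c1ccc2cc(C(=O)c3ccc(N4CCN(C(C)=O)CC4)cc3)oc2c1` gives 5150 nM.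

Compound 3 stands highest of the numbers shown; the step from its nearest neighbour is a 170-fold higher number from compound 1 to compound 3 (2.23 log units; beyond the scatter). Compound 4 `CCN(CC)c1ccc2cc(C(=O)c3ccc(N4CCN(S(=O)(=O)c5ccc(C)cc5)CC4)cc3)oc2c1` differs from it in one place: (4-methylphenyl)sulfonyl in place of acetyl on an amine nitrogen in a ring. Within the data shown here, two measured steps bear on this change. The closest is an at least 7.7-fold lower number from compound 2 to compound 3 (0.89 log units; beyond the scatter), where a related arylsulfonyl group gave a weaker compound than acetyl; the other is an at least 1300-fold higher number from compound 1 to compound 2 (3.12 log units; beyond the scatter). Because compound 2 sits at the limit of > 40000 nM in this assay, at which 1 of the 3 values shown sits, a similar outcome is expected here, and a number may not be obtained at all. For compound 4 the expected value is 40000 nM, in the range 10000 nM to 160000 nM, meaning an expected step of a 7.8-fold higher number from compound 3 to compound 4 (0.89 log units; beyond the scatter).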

Compound 4, half-maximal inhibitory concentration: 37800 nM
For compound 4 the middle estimate is 1.1-fold (0.02 log units) above the measured one; measured number inside the range.
By their numbers in this assay, from the lowest: compound 1; then compound 3; then compound 4. At a limit, above all of these: compound 2.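

The arylsulfonyl group on the ring nitrogen now has a measured number rather than a limit, so this change can be sized, and the step is modest: a 7.3-fold higher number from compound 3 to compound 4 (0.87 log units; beyond the scatter). Against the ((2,4-dichlorophenoxy)methyl)carbonyl group the loss is far larger: a 1300-fold higher number from compound 1 to compound 4 (3.10 log units; beyond the scatter). For methyl in place of bromo on an aromatic carbon, the step gives only a floor: an at least 1.0-fold lower number from compound 2 to compound 4 (0.02 log units; that floor lies within the scatter). This step cannot be read as a size, because compound 2 stands at a limit: the limit of > 40000 nM in this assay, at which 1 of the 4 values shown sits.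

Open, as far as these compounds go, is whether an amine or a carboxylic acid on that aromatic ring would bring the number down. Also open, from the compounds shown here alone, is whether a methylsulfonyl group on the ring nitrogen would behave like the arylsulfonyl groups.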